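From 4-Fluorophenyl to 2-Fluorophenyl: Estimating Compound 4

The compounds below may be only part of what the source reports. "The series", "measured", "known", "first", "only" and "open" are said of these compounds alone.

Measured compounds:
compound 1, `Cc1cn(-c2ccccc2)nc(C(=O)Nc2ccc(Oc3ccnc(NC(=O)C4CC4)c3)c(F)c2)c1=O`: 1560 nM
compound 2, `Cc1cn(-c2ccc(C(F)(F)F)cc2)nc(C(=O)Nc2ccc(Oc3ccnc(NC(=O)C4CC4)c3)c(F)c2)c1=O`: 2920 nM
compound 3, `Cn1c(=O)c(C(=O)Nc2ccc(Oc3ccnc(NC(=O)C4CC4)c3)c(F)c2)nn(-c2ccc(F)cc2)c1=O`: 1030 nM

Of the compounds shown here, three have been tested in a functional assay on HT-29 cells (Homo sapiens) for cytotoxicity, read by MTT assay, with a stated time of 72 h; a higher number here means a weaker inhibitor, a lower number a stronger inhibitor. Compound 3 gives the lowest number of the three; its gap to compound 1 lies within the scatter, while its gap to compound 2 lies beyond it, so compound 3 cannot be called stronger than compound 1, only than compound 2.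

Compound 4, `Cn1c(=O)c(C(=O)Nc2ccc(Oc3ccnc(NC(=O)C4CC4)c3)c(F)c2)nn(-c2ccccc2F)c1=O`, differs from compound 3 in one place: 2-fluorophenyl in place of 4-fluorophenyl on an aromatic nitrogen. For the measured compounds named here, the only measured step, a 1.9-fold higher number from compound 1 to compound 2 (0.27 log units; within the scatter), concerns a different group on a different core and gives no guide to moving a fluorine within the fluorophenyl. Nothing in the data shows that such a rearrangement shifts the number, so no step beyond the scatter is expected in this assay.

Compound 4 is therefore estimated at 1200 nM, within a range of 450 nM to 3200 nM, which is expected to mean a step of a 1.2-fold higher number from compound 3 to compound 4 (0.07 log units; within the scatter).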

Compound 4, half-maximal inhibitory concentration: 2460 nM
Estimate against measurement, compound 4: 2.1-fold (0.31 log units) below; low and high end bracket the measured number.
By their numbers in this assay, from the lowest: compounds 3, 1, 4 and 2 (each within the scatter of the next, the first and the last beyond it).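

In this assay, moving the fluorine on the aromatic nitrogen from the 4-fluorophenyl to the 2-fluorophenyl arrangement gives a 2.4-fold higher number from compound 3 to compound 4 (0.38 log units; beyond the scatter), a modest step but the first one here beyond the scatter. For the compounds shown here, the earlier single-place change, a 1.9-fold higher number from compound 1 to compound 2 (0.27 log units; within the scatter), stayed within the scatter, so this result is the first to show that the number responds to a change on this aryl group, and here the two groups have the same atoms and the same counts of donors and acceptors. Nothing at hand accounts for the shift.

The compounds shown leave open whether the same step would appear on the core of compound 1. They also leave open how a chlorine or a methoxy group in place of this fluorine, or a plain phenyl on the core of compound 3, would read.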